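This account rests on a few compounds, and the source may have more. Where it says the series, first, only, none or still open, it means among the compounds named here.

Compound 1 `CCCCCOc1ccc2oc(/C=C/[S+](C)[O-])cc(=O)c2c1`: 1600 nM
Compound 2 `Cc1cccc2c(=O)cc(/C=C/[S+](C)[O-])oc12`: 1700 nM
Compound 3 `Cc1c(/C=C/[S+](C)[O-])oc2ccccc2c1=O`: 1500 nM

These three compounds were tested in a functional assay on A549 cells (Homo sapiens) for cytotoxicity, with a stated time of 48 h; on this read-out higher numbers stand for weaker inhibition and lower numbers for stronger inhibition. There, compound 1 gives 1600 nM. This puts compound 1 level with the other two, since all three numbers lie within the scatter expected when one measurement is simply repeated. No ranking can be drawn from them.

The next compound to be tested is compound 4 `CCCCOc1ccc2oc(/C=C/[S+](C)[O-])cc(=O)c2c1`, which comes from compound 1 through one small edit at the end of its chain: hydrogen in place of methyl on a saturated chain carbon, four bonds along the chain from an oxygen on an aromatic ring. In words, hydrogen stands in place of methyl on a saturated chain carbon, four bonds along the chain from an oxygen on an aromatic ring.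

Within the data shown here, no measured pair shows this edit on its own, so the expectation rests on indirect evidence. Compound 2 and compound 3 differ from compound 1 by much more than this edit, yet compound 2 gives 1700 nM and compound 3 gives 1500 nM. A change no larger than the scatter, in neither direction, is therefore expected in this assay.

The estimated change is no change at the digits printed from compound 1 to compound 4 (within the scatter), which is expected to stay within the scatter.

For compound 4 the expected value is 1600 nM, with an estimated range of 800 nM to 3200 nM.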

Compound 4, half-maximal inhibitory concentration: 1400 nM
For compound 4 the middle estimate is 1.1-fold (0.06 log units) above the measured one; measured number inside the range.
By their numbers in this assay, from the lowest: compounds 4, 3, 1 and 2 (each within the scatter of the next).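

In this assay, among these compounds, replacing the methyl at the end of the chain with hydrogen gives a 1.1-fold lower number from compound 1 to compound 4 (0.06 log units; within the scatter), and this pair is the first direct reading of this edit alone, since the earlier compounds differ from one another in more than one place. The step lies within the scatter, so at this spot, four bonds along the chain from an oxygen on an aromatic ring, removing that single carbon leaves no change that this measurement can detect. No further evidence here bears on this result, so the data give no explanation for it.

As far as these compounds go, this single step covers only one small edit at the end of the chain, so it remains open whether cutting further, to a propyl or an ethyl chain, or extending to a longer chain would also stay within the scatter. From the compounds shown here alone, it also remains open whether a group of a different kind at the chain end, such as an amine or a carboxylic acid, would leave the number just as level.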